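The source may report more compounds than this note shows. Statements on the series, on what has been measured and on what is new or still open speak of the compounds shown alone.

Within the data shown here, compound 2 `O=C(CCl)Nc1ccc(SCC(=O)Nc2ccccn2)cc1` is the only member with a numbered result in a functional assay on HeLa cells (Homo sapiens) for antiproliferative activity, read by MTT assay, with a stated time of 48 h; on this read-out lower numbers stand for stronger inhibition and higher numbers for weaker inhibition: compound 2 gives 7800 nM. Compound 1 `O=C(CCl)Nc1ccc(SCC(=O)Nc2ccc(Cl)cc2)cc1` reaches only the limit (the limit of > 80000 nM in this assay, at which 1 of the 2 values shown sits), so in this assay compound 1 is recorded as > 80000 nM. Among the measured compounds shown here, the single measured step, an at least 10-fold lower number from compound 1 to compound 2 (1.01 log units; beyond the scatter), concerns the anilide end of the shared core. Compound 3 `O=C(CCCl)Nc1ccc(SCC(=O)Nc2ccccn2)cc1` differs from compound 2 at the other end: chloromethyl in place of chloro on a saturated chain carbon bound to a carbonyl carbon. For the measured compounds named here, no measured step bears on this change; the step from compound 1 to compound 2 leaves the ((chloromethyl)carbonyl)amino part untouched and gives no size to carry over. The expectation for compound 3 therefore rests on compound 2 alone, and the estimated step is a 3.2-fold higher number from compound 2 to compound 3 (0.51 log units; beyond the scatter), a higher number rather than a lower one, with wide uncertainty. Compound 3 is expected to give about 25000 nM in this assay, within 6000 nM to 80000 nM, and a limit rather than a number remains possible.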

Compound 3, half-maximal inhibitory concentration: 70400 nM
Estimate against measurement, compound 3: 2.8-fold (0.45 log units) below; the range from low to high includes it.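

The change from (chloromethyl)carbonyl to (2-chloroethyl)carbonyl gives a 9.0-fold higher number from compound 2 to compound 3 (0.96 log units; beyond the scatter) in this assay and puts a first measured size on this end of the shared core, which the earlier step at the anilide end left untouched. With pyridin-2-yl held fixed, this end of the molecule clearly bears on the read-out, and a change of 1 carbon in the chain is enough for a step beyond the scatter. Nothing measured here gives a reason for this step.

From the compounds shown here alone, whether the number keeps rising with a longer chain such as 3-chloropropyl, and what an amine or a hydroxyl group in place of the chlorine would give, stays open. Equally open, going by these compounds, is whether the same step would appear with 4-chlorophenyl on the amide-type nitrogen.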